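Opening the Ring at the Far End of the Alkyne

The source may hold more compounds than are shown below. What is called first, only, known or untested is meant among the compounds shown, and "the series" means these compounds.

Of the compounds shown here, two sharing one core have been measured in a functional assay on KG-1 cells (Homo sapiens) for antiproliferative activity; on this read-out higher numbers stand for an effect only at larger amounts of compound and lower numbers for an effect already at smaller amounts. Compound 1 `NC(=O)c1cc(Cl)c2c(Cl)c(C#CCO)n([C@H]3CCCNC3)c2n1` gives 301 nM, and compound 2 `NC(=O)c1cc(Cl)c2c(Cl)c(C#CC3CCOCC3)n([C@H]3CCCNC3)c2n1` gives 69 nM. Among the measured compounds shown here, the only step measured so far, a 4.4-fold lower number from compound 1 to compound 2 (0.64 log units; beyond the scatter), shows that replacing a small polar hydroxymethyl with a saturated ring containing one oxygen brings the number down. For the measured compounds named here, compound 2 therefore stands at the lower of the two numbers, with compound 1 as its only neighbour.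

Compound 3 `COC(C)(C)CC#Cc1c(Cl)c2c(Cl)cc(C(N)=O)nc2n1[C@H]1CCCNC1` keeps the triple bond and everything else, and changes only the group at its end: 2-methoxy-2-methylpropyl in place of oxan-4-yl on a triple-bonded carbon. The ring is opened into a branched chain while the single oxygen remains. Going by the values given here, no measured step tells how an open chain compares with the ring here; the step from compound 1 to compound 2 only shows that a larger, oxygen-containing group at this position is tolerated well. Compound 3 is therefore expected to land close to compound 2, with a step of a 1.4-fold higher number from compound 2 to compound 3 (0.14 log units; within the scatter) in this assay, within or only slightly beyond the scatter. The estimate for compound 3 is 95 nM, with a range from 35 nM to 260 nM.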

Compound 3, half-maximal effective concentration: 172 nM
Beside the measured number, compound 3's estimate is 1.8-fold (0.26 log units) below it; low and high end bracket the measured number.
By their numbers in this assay, from the lowest: compound 2; then compounds 3 and 1 (each within the scatter of the next).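

Opening the ring has a measurable cost in this assay: the change gives a 2.5-fold higher number from compound 2 to compound 3 (0.40 log units; beyond the scatter) even though oxan-4-yl and 2-methoxy-2-methylpropyl both hold 6 heavy atoms, 5 carbon and 1 oxygen, and differ in that only the first has a ring. At this place, on a triple-bonded carbon, the same atoms arranged differently therefore give a different number, so counting atoms is not enough to predict the result. The open chain also cannot be separated from the much smaller end of compound 1, with a 1.8-fold lower number from compound 1 to compound 3 (0.24 log units; within the scatter), and of the three compounds only compound 2 stands clearly apart from the others; nothing measured here explains the difference between the ring and the open chain.

The compounds shown leave open whether the oxygen itself matters, as every end group here carries one; a cyclohexyl group, with carbon in place of the ring oxygen, would test this directly. They also leave open how a ring carrying an amine, such as piperidin-4-yl, would compare with oxan-4-yl at this place.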